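Extending ethyl to butyl on the core of compound 1

The source may report more compounds than this note shows. Statements on the series, on what has been measured and on what is new or still open speak of the compounds shown alone.

In a functional assay for inhibition, with Homo sapiens as the target, tested at 2 ng/mL (on this read-out higher numbers stand for weaker inhibition and lower numbers for stronger inhibition), compound 1 `CCC1=Nc2c(OC)cccc2C(=O)C1` gives > 40000 nM, which is a limit and not a number. Its position in the series is therefore known only as the limit of > 40000 nM in this assay, at which 1 of the 3 values shown sits.

Compound 2 `Cc1ccccc1-c1nc2c(C)cccc2c(=O)o1` gives > 100000 nM, which is also a limit. Among the compounds with values here, compound 3 `Cc1ccccc1-c1nc2c(Cl)cccc2c(=O)o1` gives 91900 nM, the only value so far that is not a limit.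

The next compound to be measured is compound 4 `CCCCC1=Nc2c(OC)cccc2C(=O)C1`. It differs from compound 1 by ethyl in place of hydrogen on a saturated chain carbon, two bonds along the chain from a carbon with a double bond to nitrogen. Cut one bond further out, the same difference reads ethyl to butyl.

Within the data shown here, no measured step covers this change. Among the measured compounds shown here, the only step is an at least 1.0-fold lower number from compound 2 to compound 3 (0.03 log units; that floor lies within the scatter), with chloro in place of methyl on an aromatic carbon. That step concerns another group on another core, so it bears on the present change only indirectly, as the sole indication of how small a single change can be here.

On that thin basis, no step beyond the scatter is expected, and no direction can be assigned with confidence. The expected step is a step that the limit leaves unreadable from compound 1 to compound 4. For compound 4 the estimated value is 50000 nM, with an expected range of 20000 nM to 120000 nM.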

Compound 4, half-maximal inhibitory concentration: > 100000 nM
Compound 4: no number, only a limit; the forecaster's own chance of this, stated with the estimate: 60%; at least 2.0-fold (0.30 log units) between middle value and limit.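

In this assay compound 1 gives > 40000 nM, a limit and not a number. Within the data shown here, compound 4 gives > 100000 nM, also a limit, so no step from compound 1 to compound 4 can be read. The compounds shown leave open whether ethyl to butyl on the shared core changes inhibition at all, and in which direction.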